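Exchanging the Para Substituent on the Sulfonate Aryl Ring

A few compounds are considered here, and "the series" means these few. Any claim that something is new, unique, unknown or untested is made for them only; others in the source may bear on it.

For the measured compounds named here, compound 2 `CNC(=O)/C=C1/COc2cc(OS(=O)(=O)c3ccc(C#N)cc3)ccc21` gives 45 nM in an assay (strain Sprague-Dawley) for inhibition of Amine oxidase [flavin-containing] A (Rattus norvegicus), read by spectrophotometry, with a stated time of 5 min (on this read-out higher numbers stand for weaker inhibition and lower numbers for stronger inhibition), the highest of the two numbers so far. Going by the values given here, its nearest neighbour is compound 1 `CNC(=O)/C=C1/COc2cc(OS(=O)(=O)c3ccc(Cl)cc3)ccc21`, which in this assay gives 12 nM; the only measured step, a 3.8-fold higher number from compound 1 to compound 2 (0.57 log units; beyond the scatter), runs through cyano in place of chloro on an aromatic carbon. Compound 3 `CNC(=O)/C=C1/COc2cc(OS(=O)(=O)c3ccc(OC)cc3)ccc21` is reached from compound 2 by methoxy in place of cyano on an aromatic carbon. Among the compounds with values here, no measured step swaps cyano for methoxy, so the step from compound 1 to compound 2 bears on the change only indirectly, in showing that exchanging the group on that aromatic carbon shifts the number by a modest amount. On that basis a shift of similar size is expected, most likely back toward the number of compound 1, so compound 3 is expected to move by a 1.8-fold lower number from compound 2 to compound 3 (0.26 log units; within the scatter). Compound 3 is therefore estimated at 25 nM, within a range of 8 nM to 80 nM.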

Compound 3, half-maximal inhibitory concentration: 11 nM
For compound 3 the middle estimate is 2.3-fold (0.36 log units) above the measured one, within the range that was stated.
By their numbers in this assay, from the lowest: compounds 3 and 1 (each within the scatter of the next); then compound 2.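

In this assay the exchange of cyano for methoxy on this aromatic carbon gives a 4.1-fold lower number from compound 2 to compound 3 (0.61 log units; beyond the scatter) and so registers as a real step. The other new step, a 1.1-fold lower number from compound 1 to compound 3 (0.04 log units; within the scatter) for methoxy in place of chloro, leaves those two groups level, so among the three groups shown only cyano stands apart, which the first pair alone could not reveal. No measurement offered here accounts for why the nitrile differs from the other two groups.

The compounds shown leave open whether cyano is a lone exception or one of several groups that raise the number on this carbon. An amine, a carboxylic acid or a longer chain such as butoxy at this place could fall on either side, and the three compounds give no way of telling which.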